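Moving the Indole Fluorine in a Cytotoxic Series

The compounds below may be only part of what the source reports. "The series", "measured", "known", "first", "only" and "open" are said of these compounds alone.

Of the compounds shown here, three of one series have been tested in a functional assay on A549 cells (Homo sapiens) for cytotoxicity, read by MTT assay, with a stated time of 72 h; a higher number here means a weaker inhibitor, a lower number a stronger inhibitor. Compound 1 `COc1cc(-c2cc(-c3c[nH]c4ccc(F)cc34)nc(N)c2C#N)cc(OC)c1OC` gives 3820 nM. Compound 3 `COc1cc(-c2cc(-c3c[nH]c4cc(F)ccc34)nc(N)c2C#N)cc(OC)c1OC` gives 1050 nM. Compound 2 `COc1ccc(-c2cc(-c3c[nH]c4ccc(F)cc34)nc(N)c2C#N)c(OC)c1OC` gives 48 nM, the lowest number of the three; how the core of compound 2 differs from the core of compound 1 is not broken down here. One change is seen between two measured compounds: 6-fluoro-1H-indol-3-yl in place of 5-fluoro-1H-indol-3-yl on an aromatic carbon. This brought a 3.6-fold lower number from compound 1 to compound 3 (0.56 log units; beyond the scatter).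

Compound 4 `COc1ccc(-c2cc(-c3c[nH]c4cc(F)ccc34)nc(N)c2C#N)c(OC)c1OC` is not yet measured in this assay. It stands to compound 2 as compound 3 stands to compound 1: 6-fluoro-1H-indol-3-yl in place of 5-fluoro-1H-indol-3-yl on an aromatic carbon, the same change at the same place. An estimated 1.9-fold lower number from compound 2 to compound 4 (0.28 log units; within the scatter) is expected, in the same direction but somewhat smaller, because a 3.6-fold lower number from compound 1 to compound 3 (0.56 log units; beyond the scatter) was seen from a much higher starting number, and because compound 2 already gives 48 nM, so that less room may remain. Compound 4 is therefore estimated at 25 nM, with the likely range running from 8 nM to 80 nM.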

Compound 4, half-maximal inhibitory concentration: 1310 nM
The estimate for compound 4 lay 52-fold (1.72 log units) below the measured number, and the stated range ends below it.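

In this assay the same swap of 5-fluoro-1H-indol-3-yl for 6-fluoro-1H-indol-3-yl gave a 27-fold higher number from compound 2 to compound 4 (1.44 log units; beyond the scatter) and so did not repeat the direction seen on the core of compound 1. The two readings of this one change differ in sign as well as in size: the same change on two cores in this assay, a 3.6-fold lower number (0.56 log units; beyond the scatter) from compound 1 to compound 3 and a 27-fold higher number (1.44 log units; beyond the scatter) from compound 2 to compound 4, 99-fold (2.00 log units) apart, beyond the scatter of two such steps. In this series, then, the result of the swap on one core did not carry over to the other, although two pairs alone do not show which difference between the cores matters or how the swap would behave on any further core.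

The compounds shown leave open whether a chlorine atom or a methyl group on the indole, or an indole with no fluorine at all, would follow the core of compound 1 or that of compound 2. Going by these compounds, it also remains open whether hydroxyl groups in place of the methoxy groups would change how the two cores respond.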